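A chlorine-to-methyl swap on the pyridine amine

A few compounds are considered here, and "the series" means these few. Any claim that something is new, unique, unknown or untested is made for them only; others in the source may bear on it.

Compound 1 `Cc1ccc(-n2nccn2)c(C(=O)N2CC3(CC3)C[C@H]2CNc2ccc(Cl)cn2)c1` gives 8.1 in a functional assay on CHO cells for antagonist activity at Orexin/Hypocretin receptor type 1 (Homo sapiens), read by FLIPR and calcium flux; on this read-out lower numbers stand for lower potency and higher numbers for higher potency (the scale is a negative logarithm). Compound 2 `Cc1ccc(-n2nccn2)c(C(=O)N2CCC3(CC3)C[C@H]2CNc2cccc(C)n2)c1` gives 8.2 and compound 3 `Cc1ccc(-c2ncccn2)c(C(=O)N2CC3(CC3)C[C@H]2CNc2ccc(Cl)cn2)c1` gives 8.2, so compound 1 sits within the usual scatter of both. Compound 4 `Cc1ccc(-n2nccn2)c(C(=O)N2CC3(CC3)C[C@H]2CNc2cccc(C)n2)c1` carries 6-methylpyridin-2-yl in place of 5-chloropyridin-2-yl on an amine nitrogen. Among the measured compounds shown here, no measured step covers this exact change; the only single step, a number 0.10 log units higher from compound 1 to compound 3 (within the scatter), concerns a different part of the molecule and stays within the scatter. Compound 2, which carries the same 6-methylpyridin-2-yl group on a different core, shows a value within the scatter of compound 1, so no shift beyond the scatter is expected. Compound 4 is therefore estimated at 8.1, with a range from 7.6 to 8.6, an expected step of no change at the digits printed from compound 1 to compound 4 (within the scatter).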

Compound 4, negative logarithm of the antagonist equilibrium constant: 7.1
Beside the measured number, compound 4's estimate is 1.00 log units above it, and the stated range ends above it.
By their numbers in this assay, from the lowest: compound 4; then compounds 1, 2 and 3 (each within the scatter of the next).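

In this assay, the group on the amine nitrogen proves sensitive: 6-methylpyridin-2-yl in place of 5-chloropyridin-2-yl, with the same count of heavy atoms, gives a number 1.00 log units lower from compound 1 to compound 4 (beyond the scatter). With the same 6-methylpyridin-2-yl group on a different core, compound 2 gives 8.2, against compound 4 with 7.1, so the group alone does not set the number. Nothing shown explains this drop. Still open, from the compounds shown here alone, is whether removing the chlorine or placing a group elsewhere on the pyridine matters more: 5-methylpyridin-2-yl and 6-chloropyridin-2-yl would separate the two.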